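Aryl variation on the ring nitrogen of compound 3

The source may report more compounds than this note shows. Statements on the series, on what has been measured and on what is new or still open speak of the compounds shown alone.

Measured so far:
compound 1, `O=C1Nc2ccc(Cl)cc2/C1=N/NC(=S)N1CCN(c2ccccc2)CC1`: 10400 nM
compound 2, `COc1ccc(N2CCN(C(=S)N/N=C3\C(=O)Nc4ccc(Cl)cc43)CC2)cc1`: 13800 nM
compound 3, `O=C1Nc2ccc(Cl)cc2/C1=N/NC(=S)N1CCN(c2ccc(F)cc2F)CC1`: 20100 nM

All three numbers come from a functional assay on MCF7 cells (Homo sapiens) for inhibition, read by MTT assay, with a stated time of 72 h; a lower number here means a stronger inhibitor, a higher number a weaker inhibitor. Compound 3 gives the highest of the three, yet every step to it lies within the scatter: a 1.9-fold higher number from compound 1 to compound 3 (0.29 log units; within the scatter) and a 1.5-fold higher number from compound 2 to compound 3 (0.16 log units; within the scatter); the step of a 1.3-fold higher number from compound 1 to compound 2 (0.12 log units; within the scatter) is likewise within the scatter. The change to compound 4, `O=C1Nc2ccc(Cl)cc2/C1=N/NC(=S)N1CCN(c2ccccc2[N+](=O)[O-])CC1`, is 2-nitrophenyl in place of 2,4-difluorophenyl on an amine nitrogen in a ring. The three measured steps bear on it directly, since each also swaps the group on that ring nitrogen, and none moved the number beyond the scatter. The expected step is therefore a 1.3-fold lower number from compound 3 to compound 4 (0.13 log units; within the scatter), which is no larger than the scatter. Compound 4 is estimated at 15000 nM in this assay, with a range from 7000 nM to 35000 nM.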

Compound 4, half-maximal inhibitory concentration: 7490 nM
Beside the measured number, compound 4's estimate is 2.0-fold (0.30 log units) above it; the range from low to high includes it.
By their numbers in this assay, from the lowest: compounds 4, 1, 2 and 3 (each within the scatter of the next, the first and the last beyond it).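

Going by these compounds alone, on the ring nitrogen, the change gives a 2.7-fold lower number from compound 3 to compound 4 (0.43 log units; beyond the scatter) in this assay and is the only step to pass the scatter, so the aryl group at this place can shift the number. The other steps, a 1.8-fold lower number from compound 2 to compound 4 (0.27 log units; within the scatter) and a 1.4-fold lower number from compound 1 to compound 4 (0.14 log units; within the scatter), stay within the scatter, so nitro in place of hydrogen has no clear effect and compound 4 separates from compound 3 alone. No measurement shown accounts for the shift.

Open, as far as these compounds go, is whether a benzyl or cyclohexyl group on this nitrogen would keep the number in this range.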